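Three aryl-triazole analogues at the assay limit, one more to come

A few compounds are considered here, and "the series" means these few. Any claim that something is new, unique, unknown or untested is made for them only; others in the source may bear on it.

Measured so far:
- compound 1, `O=C1N[C@H]2[C@H](CS[C@H]2CCCCCc2cn(Cc3ccccc3O)nn2)N1`: > 16000 nM
- compound 2, `O=C1N[C@H]2[C@H](CS[C@H]2CCCCCc2cn(Cc3cccc(O)c3)nn2)N1`: > 16000 nM
- compound 3, `O=C1N[C@H]2[C@H](CS[C@H]2CCCCCc2cn(Cc3ccc(F)cc3)nn2)N1`: > 16000 nM

In an assay on isolated protein for inhibition of biotin--protein ligase (Homo sapiens), read by scintillation counting, with a stated time of 10 min (a lower number here means a stronger inhibitor, a higher number a weaker inhibitor), compound 1 gives > 16000 nM, which is a limit of the assay and not a number. Compound 2 likewise gives only a limit, > 16000 nM. Compound 3 also sits at a limit, > 16000 nM. Compound 1 therefore stands on no number at all; it shares the limit with the other two, as shown by the limit of > 16000 nM in this assay, at which 3 of the 3 values shown sit.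

Compound 4, `O=C1N[C@H]2[C@H](CS[C@H]2CCCCCc2cn(Cc3cccc(Cl)c3)nn2)N1`, differs from compound 1 in one place: 3-chlorophenyl in place of 2-hydroxyphenyl on a saturated chain carbon bound to an aromatic nitrogen. Among the compounds with values here, the steps that bear on this change are a step that the two limits leave unreadable from compound 1 to compound 2 and a step that the two limits leave unreadable from compound 1 to compound 3, both unreadable in size. Within the data shown here, with only limits to go by, no step in this assay can be expected in either direction; the best expectation for compound 4 is another limit.

The step from compound 1 to compound 4 is expected to be a number no higher from compound 1 to compound 4 (the limit leaves the size open). Compound 4 is thus estimated at 16000 nM, within 5000 nM to 50000 nM.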

Compound 4, inhibition constant: > 16000 nM
Compound 4: no number, only a limit; the forecaster's own chance of this, stated with the estimate: 80%; the middle value lies on the limit itself.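

In this assay compound 4 gives > 16000 nM, which is a limit and not a number. No step among compound 1, compound 2, compound 3 and compound 4 can be read, since all share one limit: the limit of > 16000 nM in this assay, at which 4 of the 4 values shown sit.

On these data alone, how these four aryl groups rank against one another, and whether any change to the shared core gives a real number, stays open.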